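Replacing phenyl with hexyl on a carbonyl carbon

This account rests on a few compounds, and the source may have more. Where it says the series, first, only, none or still open, it means among the compounds named here.

- Compound 1 `CC(NC(=O)CN)C(=O)N(C)c1ccc(Cl)cc1C(=O)c1ccccc1Cl`: 0.47 mg/kg
- Compound 2 `CN(C(=O)CNC(=O)c1ccccc1)c1ccc(Cl)cc1C(=O)c1ccccc1Cl`: 2.9 mg/kg

Among the measured compounds shown here, in a functional assay on the whole organism for antagonist activity, with Mus musculus as the target (on this read-out lower numbers stand for an effect already at smaller amounts and higher numbers for an effect only at larger amounts of compound), compound 2 gives 2.9 mg/kg, the higher of the two numbers so far, so it needs the larger dose for its effect. For the measured compounds named here, the only measured step, a 6.2-fold higher number from compound 1 to compound 2 (0.79 log units; beyond the scatter), is modest but beyond the scatter. It replaced a larger piece of the molecule, one that includes the phenyl now in question.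

Compound 3 `CCCCCCC(=O)NCC(=O)N(C)c1ccc(Cl)cc1C(=O)c1ccccc1Cl` keeps the shared core and carries hexyl in place of phenyl on a carbonyl carbon. Going by the values given here, an aromatic ring leaves and an open chain enters, and no measured pair compares these two groups directly. Among the compounds with values here, the one measured step therefore serves only as a rough guide to size. A change no larger than that step is expected in this assay, and nothing measured fixes its direction, although a slight rise seems somewhat more likely. The estimated change is a 1.4-fold higher number from compound 2 to compound 3 (0.14 log units; within the scatter). For compound 3 the estimated value is 4 mg/kg, with an expected range of 1.2 mg/kg to 13 mg/kg.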

Compound 3, dose for half-maximal effect: 1.9 mg/kg
Estimate against measurement, compound 3: 2.1-fold (0.32 log units) above; low and high end bracket the measured number.
By their numbers in this assay, from the lowest: compound 1; then compounds 3 and 2 (each within the scatter of the next).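

In this assay, exchanging the aromatic ring for an open chain at this position, on a carbonyl carbon bonded to an amide-type nitrogen, gives a 1.5-fold lower number from compound 2 to compound 3 (0.18 log units; within the scatter). On this read-out, then, phenyl and hexyl cannot be told apart here, even though one group is a ring and the other has no ring. Compound 3 nevertheless stays clearly separate from compound 1, with a 4.0-fold higher number from compound 1 to compound 3 (0.61 log units; beyond the scatter), so both compounds that lack the 1-(((aminomethyl)carbonyl)amino)ethyl group need a dose beyond the scatter of that of compound 1, while no information is available on what lies behind these numbers.

Still open, on these data alone, is how far this tolerance extends on the same carbonyl carbon: a shorter chain such as butyl, a longer chain such as octyl, or a hexyl chain ending in an amine could each behave differently. Also open is which part of the larger group in compound 1 accounts for its separation from compound 3, the aminomethyl end or the extra methyl on the ethyl carbon.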